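Amide in place of acid on a furan-type core

The source may report more compounds than this note shows. Statements on the series, on what has been measured and on what is new or still open speak of the compounds shown alone.

Compound 1 `C=CC1=C(C(=O)O)C(c2ccc(F)cc2)OC1` gives in a functional assay on A549 cells (Homo sapiens) for cytotoxicity, read by MTT assay, with a stated time of 24 h (on this read-out lower numbers stand for stronger inhibition and higher numbers for weaker inhibition), the value > 100000 nM.
Compound 2 `C=CC1=C(C(=O)NCCCCC)C(c2ccc(Cl)c(Cl)c2)OC1` gives in this assay the value > 100000 nM.
Compound 3 `C=CC1=C(C(=O)O)C(c2ccc(OC)cc2)OC1` gives in this assay the value > 100000 nM.

Compound 1 stands only at a limit of this assay, not at a number. Compound 3 also sits at a limit, so the step that the two limits leave unreadable from compound 1 to compound 3, methoxy in place of fluoro on an aromatic carbon, cannot be read. The same holds for compound 2, whose value is a limit as well; all three measured compounds share this position, as noted in the limit of > 100000 nM in this assay, at which 3 of the 3 values shown sit.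

Compound 4 `C=CC1=C(C(=O)Nc2ccc(C)cc2)C(c2ccc(F)cc2)OC1` differs from compound 1 by (4-methylphenyl)amino in place of hydroxy on a carbonyl carbon. Among the compounds with values here, no measured step bears directly on this change. Compound 2, which carries an amide on the same carbonyl carbon, and compound 1 both show only the limit, so nothing suggests that an amide brings the value into the readable range. Compound 4 is therefore expected to remain at the limit, and its estimated step of a number no higher from compound 1 to compound 4 (the limit leaves the size open) is none beyond the scatter. The estimate for compound 4 is 100000 nM, with a range from 30000 nM to 300000 nM.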

Compound 4, half-maximal inhibitory concentration: > 100000 nM
Compound 4 ended at the assay's limit; the forecaster's own chance of this, stated with the estimate: 85%; the middle value lies on the limit itself.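

Compound 4, like compound 1, stands only at a limit and not at a number, so no size can be read for the change between these two compounds: the limit of > 100000 nM in this assay, at which 4 of the 4 values shown sit.

The compounds shown leave open whether any change on the shared core brings a value into the readable range of this assay.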